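Swapping a Pyridinylmethyl Arm for a Fluorophenyl Arm

The source may hold more compounds than are shown below. What is called first, only, known or untested is meant among the compounds shown, and "the series" means these compounds.

Compound 1 `Nc1ccccc1NC(=O)c1ccc(CSC(=S)N2CCN(Cc3ccccn3)CC2)cc1` was tested in a functional assay on HeLa cells (Homo sapiens) for antiproliferative activity, read by CCK-8 assay, with a stated time of 72 h, tested at 2 uM (a higher number here means a stronger effect of the compound at the concentration tested, a lower number a weaker effect), and gives 14.2%. Compound 3 `Nc1ccccc1NC(=O)c1ccc(CSC(=S)N2CCN(C(c3ccccc3)c3ccccc3)CC2)cc1` gives 8% in this assay, a number within the usual scatter of that of compound 1, so the two cannot be ordered. Compound 2 `Nc1ccccc1NC(=O)c1ccc(CSC(=S)N2CCc3ccc([N+](=O)[O-])cc32)cc1` gives 45.7%, which lies beyond the scatter above compound 1. Compound 1 thus sits between compound 2 and compound 3 on the numbers shown. Compound 4 `Nc1ccccc1NC(=O)c1ccc(CSC(=S)N2CCN(c3ccccc3F)CC2)cc1` differs from compound 1 in one place: 2-fluorophenyl in place of (pyridin-2-yl)methyl on an amine nitrogen in a ring. Among the measured compounds shown here, no measured pair isolates this change, and the two compounds carrying different groups on the same amine nitrogen in a ring, compound 1 and compound 3, differ only within the scatter. The step of a number 0.8 percentage points higher from compound 1 to compound 4 (within the scatter) is therefore expected to be small, with no direction beyond the scatter. Compound 4 is estimated at 15%, within a range from 5% to 30%.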

Compound 4, a percentage reported as inhibition, at one concentration (the size of the read-out at that concentration, not a potency): 17.5%
Compound 4: middle estimate off by 2.5 percentage points, on the low side, and the stated range covers the measured number.
By their numbers in this assay, from the lowest: compounds 3, 1 and 4 (each within the scatter of the next); then compound 2.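

Among the compounds shown here, putting 2-fluorophenyl in place of (pyridin-2-yl)methyl on this amine nitrogen in a ring gives, in this assay, a number 3.3 percentage points higher from compound 1 to compound 4 (within the scatter), the first step measured between compounds that differ in one place. At this position, then, an aromatic ring of carbon only bearing fluorine and an aromatic ring with a hetero atom on a methyl link cannot be told apart at the concentration tested. No measurement at hand offers an explanation for this step. From the compounds shown here alone, whether a smaller group such as methyl or acetyl on the same nitrogen would stay within the scatter of compound 1 remains open.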